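The source may report more compounds than this note shows. Statements on the series, on what has been measured and on what is new or still open speak of the compounds shown alone.

Working notes on the series. Compound 1 `COc1cc(O)c(C(=O)OC(C)C)c(/C=C/CN2C(=O)C=CC2=O)c1` carries an isopropyl ester together with a maleimide on the side chain; in a functional assay on THP-1 cells (Homo sapiens) for antiproliferative activity, read by luminescence, with a stated time of 72 h (on this read-out lower numbers stand for stronger inhibition and higher numbers for weaker inhibition), compound 1 gives 7320 nM. Compound 2 `C=CS(=O)(=O)NC/C=C/c1cc(OC)cc(O)c1C(=O)OCc1ccc(Br)cc1` and compound 3 `C=CS(=O)(=O)NC/C=C/c1cc(OC)cc(O)c1C(=O)OCc1ccc(F)cc1` instead carry a vinylsulfonamide on the side chain and a substituted benzyl ester; in this assay compound 2 gives 6240 nM and compound 3 gives 6550 nM. Within the data shown here, the only single-point step among the measured compounds is a 1.0-fold higher number from compound 2 to compound 3 (0.02 log units; within the scatter), a fluoro in place of bromo on an aromatic carbon. On the numbers shown, compound 3 stands second highest of the three, and its gaps to compound 2 and to compound 1 are both within the scatter.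

Compound 4 `C=CS(=O)(=O)NC/C=C/c1cc(OC)cc(O)c1C(=O)OC(C)C` differs from compound 3 by isopropyl in place of 4-fluorobenzyl on an oxygen next to a carbonyl group. Among the measured compounds shown here, no measured step bears directly on this change: the halogen swap concerns a different part of the ester, and the pair of compound 1 and compound 3 differs in two places, though their values show no separation beyond the scatter. The isopropyl ester of compound 1 sits in the same narrow band as the benzyl esters, so for this assay no step beyond the scatter is expected, a 1.1-fold higher number from compound 3 to compound 4 (0.03 log units; within the scatter). Compound 4 is therefore estimated at 7000 nM, with a range from 3000 nM to 16000 nM.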

Compound 4, half-maximal inhibitory concentration: 14700 nM
The estimate for compound 4 lay 2.1-fold (0.32 log units) below the measured number, and the stated range covers the measured number.
By their numbers in this assay, from the lowest: compounds 2, 3, 1 and 4 (each within the scatter of the next, the first and the last beyond it).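

In this assay, among these compounds, the ester oxygen gives the first single change that lies beyond the scatter: isopropyl in place of the halogenated benzyl groups gives a 2.2-fold higher number from compound 3 to compound 4 (0.35 log units; beyond the scatter) and a 2.4-fold higher number from compound 2 to compound 4 (0.37 log units; beyond the scatter), both modest steps. With the isopropyl ester held, the vinylsulfonamide in place of the maleimide gives a 2.0-fold higher number from compound 1 to compound 4 (0.30 log units; within the scatter), so these two side chains are not separated here. No measurement in hand explains the ester step.

Still open, on these data alone, is whether a benzyl ester without a halogen, or a free carboxylic acid in place of the ester, would fall with the halogenated benzyl esters or with the isopropyl ester. Also open, as far as these compounds go, is whether the same ester change would give a step of similar size with the maleimide side chain.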